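A bromophenyl swap on a sulfonyl sulfur, checked for cell tolerance

The compounds below may be only part of what the source reports. "The series", "measured", "known", "first", "only" and "open" are said of these compounds alone.

Of the compounds shown here, three with a shared core have been measured in a functional assay on HEK293 cells (Homo sapiens) for cytotoxicity (a higher number here means that more compound is tolerated, a lower number that less compound is tolerated), so far. Compound 1 (`COc1ccc([C@H]2CC(=O)N(c3cccc(S(C)(=O)=O)c3)C2)cc1OC1CCCC1`) gives > 10000 nM there, which is a limit and not a number. Compound 2 (`COc1ccc([C@H]2CC(=O)N(c3cccc(NCc4ccoc4)c3)C2)cc1OC1CCCC1`) gives > 10000 nM and this too is a limit. Compound 3 (`COc1ccc([C@H]2CC(=O)N(c3cccc(NS(=O)(=O)c4c(F)cccc4F)c3)C2)cc1OC1CCCC1`) gives > 10000 nM and this is also a limit. Compound 3 therefore has no exact position, and the whole set sits together: the limit of > 10000 nM in this assay, at which 3 of the 3 values shown sit, gives the picture.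

Compound 4 (`COc1ccc([C@H]2CC(=O)N(c3cccc(NS(=O)(=O)c4cccc(Br)c4)c3)C2)cc1OC1CCCC1`) differs from compound 3 in one group: 3-bromophenyl in place of 2,6-difluorophenyl on a sulfonyl sulfur describes it, with 3-bromophenyl in place of 2,6-difluorophenyl on a sulfonyl sulfur.

The closest measured change alters the same substituent on the nitrogen, and it is a step that the two limits leave unreadable from compound 2 to compound 3 in size. The two changes made at the same spot on the aromatic ring are a step that the two limits leave unreadable from compound 1 to compound 2 and a step that the two limits leave unreadable from compound 1 to compound 3 in size. None of these gives a readable size, so no shift in either direction can be argued. The expected result is a step that the limit leaves unreadable from compound 3 to compound 4 and most likely this assay will again return only a limit. The estimate for compound 4 is 20000 nM and from 7000 nM to 50000 nM is the range expected.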

Compound 4, half-maximal cytotoxic concentration: > 10000 nM
Compound 4: no number, only a limit; the forecaster's own chance of this, stated with the estimate: 85%; the middle value does not contradict the limit.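

No step between compound 4 and compound 1, compound 2 or compound 3 can be read in this assay, since all four compounds return only a limit: the limit of > 10000 nM in this assay, at which 4 of the 4 values shown sit.

The compounds shown leave open at what concentration any of the four harms these cells, and whether 3-bromophenyl and 2,6-difluorophenyl on the sulfonyl sulfur differ in this respect.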